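Trading the benzyl group for an allyl chain

A few compounds are considered here, and "the series" means these few. Any claim that something is new, unique, unknown or untested is made for them only; others in the source may bear on it.

Compound 1, `NC(=O)c1cn(Cc2ccccc2)c2ncnc(N)c12`, in a functional assay on KB cells (Homo sapiens) for cytotoxicity (on this read-out lower numbers stand for stronger inhibition and higher numbers for weaker inhibition), gives 75000 nM.
Compound 2, `CC(C)(C)c1ccc(Cn2cc(C(N)=O)c3c(N)ncnc32)cc1`, in this assay gives 900 nM.
Compound 3, `N#Cc1cn(Cc2ccccc2)c2ncnc(N)c12`, in this assay gives only a limit, > 100000 nM.

Compound 1 stands highest of the two numbers in hand. The nearest number belongs to compound 2, reached by an 83-fold lower number from compound 1 to compound 2 (1.92 log units; beyond the scatter). Compound 3 sits at the limit of > 100000 nM in this assay, at which 1 of the 3 values shown sits, so its step is bounded only: an at least 1.3-fold higher number from compound 1 to compound 3 (0.12 log units; that floor lies within the scatter).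

Compound 4, `C=CCn1cc(C(N)=O)c2c(N)ncnc21`, differs from compound 1 by vinyl in place of phenyl on a saturated chain carbon bound to an aromatic nitrogen. Among the measured compounds shown here, of the measured steps, the one to compound 2 bears most, since it alters the same phenyl group, adding tert-butyl and producing a large lowering; the step to compound 3 changes a different place and says little here. With the phenyl gone entirely, a movement in the opposite direction, toward higher numbers, is expected, though the small starting margin to the limit means a limit may be all that is reported. Compound 4 is estimated at 150000 nM, within 50000 nM to 400000 nM, which is expected to mean a 2.0-fold higher number from compound 1 to compound 4 (0.30 log units; within the scatter).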

Compound 4, half-maximal inhibitory concentration: 100000 nM
Estimate against measurement, compound 4: 1.5-fold (0.18 log units) above; the range from low to high includes it.
By their numbers in this assay, from the lowest: compound 2; then compounds 1 and 4 (each within the scatter of the next).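

In this assay, vinyl in place of phenyl on a saturated chain carbon bound to an aromatic nitrogen gives a 1.3-fold higher number from compound 1 to compound 4 (0.12 log units; within the scatter), so at this place the plain phenyl makes no difference that can be told from the scatter. The same group is not indifferent to change, however: it is only with tert-butyl added, in an 83-fold lower number from compound 1 to compound 2 (1.92 log units; beyond the scatter), that the number falls. How far a number could rise above that of compound 1 stays unseen, since compound 3 gives a limit and not a number: the limit of > 100000 nM in this assay, at which 1 of the 4 values shown sits.

From the compounds shown here alone, whether a saturated propyl chain or a longer chain would read any differently from vinyl remains open. So does whether a methoxy group, an amine or a carboxylic acid in place of tert-butyl would also lower the number.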